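A few compounds are considered here, and "the series" means these few. Any claim that something is new, unique, unknown or untested is made for them only; others in the source may bear on it.

Working notes on the series, read in a functional assay, read by Griess assay, with a stated time of 2.5 h; a higher number here means a weaker inhibitor, a lower number a stronger inhibitor. Of the compounds shown here, three have numbers so far. Compound 1 `COc1cc(OC)c(OC)cc1/C=C/C(=O)c1cc(Cc2ccccc2)cc(Cc2ccccc2)c1` gives 2.09 ug/mL, compound 2 `COc1cc(OC)c(-c2cc(=O)c3cc(Cl)ccc3o2)cc1OC` gives 2.15 ug/mL, and compound 3 `COc1cc(OC)c(OC)cc1/C=C/C(=O)c1ccc(O)cc1O` gives 2.76 ug/mL. Compound 3 lies within the scatter of both of the others, so these values set no ranking among the three compounds.

The next compound is compound 4 `COc1cc(OC)c(OC)cc1/C=C/C(=O)c1ccc(Br)cc1`, which has 4-bromophenyl in place of 2,4-dihydroxyphenyl on a carbonyl carbon. For the measured compounds named here, no two measured compounds differ in only one place, so the series offers no measured step to carry over to this change. Going by the values given here, the only guide is the narrow spread of the values: compound 3 at 2.76 ug/mL and compound 1 at 2.09 ug/mL remain within the scatter of each other despite their different structures. On that limited basis, no shift beyond the scatter is expected in this assay, and neither direction is favoured with any confidence. The expected step is a 1.1-fold higher number from compound 3 to compound 4 (0.04 log units; within the scatter). The range is kept wide since this change has not been tested in the series. For compound 4, the estimated value is 3 ug/mL, with an expected range of 1.2 ug/mL to 7.5 ug/mL.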

Compound 4, half-maximal inhibitory concentration: 2.22 ug/mL
For compound 4 the middle estimate is 1.4-fold (0.13 log units) above the measured one; measured number inside the range.
By their numbers in this assay, from the lowest: compounds 1, 2, 4 and 3 (each within the scatter of the next).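

For the compounds shown here, compound 3 and compound 4 form the first pair that differs in one place, and in this assay exchanging 2,4-dihydroxyphenyl for 4-bromophenyl on a carbonyl carbon gives a 1.2-fold lower number from compound 3 to compound 4 (0.09 log units; within the scatter) as the only step so far. At this position, then, the hydrogen-bond donors and acceptors counted on 2,4-dihydroxyphenyl are absent from 4-bromophenyl, yet the two compounds remain within the scatter of each other. This single pair shows that these two groups cannot be told apart in this read-out, although it cannot separate the loss of the hydroxy groups from the arrival of the bromine. No measurement is available that would explain this result.

Still open, going by these compounds, is whether the position stays as tolerant with a 4-hydroxyphenyl, which would separate those two parts of the change, or with a phenyl ring carrying an amine or a carboxylic acid. Going by these compounds alone, with only one step available, it also remains unknown whether a change on this carbonyl carbon can move the number beyond the scatter at all.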